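The source may report more compounds than this note shows. Statements on the series, on what has been measured and on what is new or still open speak of the compounds shown alone.

Measured in an ADME assay on MT4 cells (Homo sapiens) for cytotoxicity, read by MTT assay; a higher number here means that more compound is tolerated, a lower number that less compound is tolerated:
Compound 1 `Cc1ccc(N(C(=O)c2ccccc2[N+](=O)[O-])C(=S)OCCN2C(=O)c3ccccc3C2=O)cc1`: 100000 nM
Compound 2 `Cc1ccc(N(C(=O)c2cc(F)cc(F)c2)C(=S)OCCN2C(=O)c3ccccc3C2=O)cc1`: 54000 nM

Compound 2, at 54000 nM, lies within the scatter of compound 1, at 100000 nM, so the two cannot be ranked. Compound 3 `Cc1ccc(N(C(=O)c2ccc([N+](=O)[O-])cc2Cl)C(=S)OCCN2C(=O)c3ccccc3C2=O)cc1` has not yet been measured. It carries 2-chloro-4-nitrophenyl in place of the 3,5-difluorophenyl of compound 2 on a carbonyl carbon: 2-chloro-4-nitrophenyl in place of 3,5-difluorophenyl on a carbonyl carbon.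

Going by the values given here, only one measured step bears on this change, and it falls at the same place. In that step, 3,5-difluorophenyl replaces 2-nitrophenyl, giving a 1.9-fold lower number from compound 1 to compound 2 (0.27 log units; within the scatter), which stays within the scatter. Among the compounds with values here, no compound with the 2-chloro-4-nitrophenyl group has been measured, so this single step is thin support. On that evidence, no step beyond the scatter is expected in this assay. The expected change is a 1.2-fold higher number from compound 2 to compound 3 (0.08 log units; within the scatter), and this estimate carries no clear direction. For compound 3 the estimated value is 65000 nM, with an expected range of 28000 nM to 110000 nM.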

Compound 3, half-maximal cytotoxic concentration: 17000 nM
Estimate against measurement, compound 3: 3.8-fold (0.58 log units) above, and the stated range ends above it.
By their numbers in this assay, from the lowest: compound 3; then compounds 2 and 1 (each within the scatter of the next).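

In this assay, the group on this carbonyl carbon now separates compounds: 2-chloro-4-nitrophenyl in place of 3,5-difluorophenyl gives a 3.2-fold lower number from compound 2 to compound 3 (0.50 log units; beyond the scatter), and 2-chloro-4-nitrophenyl in place of 2-nitrophenyl gives a 5.9-fold lower number from compound 1 to compound 3 (0.77 log units; beyond the scatter). The earlier change at this place stayed within the scatter, whereas compound 3 stands beyond the scatter from both other compounds, with the lowest number of the three. Compound 1 also carries a nitro group, as its 2-nitrophenyl name shows, so a nitro group alone does not go with the lower number here, and nothing measured on these compounds accounts for the step.

The compounds shown do not separate the chlorine from the nitro group in this result, since 2-chlorophenyl and 4-nitrophenyl are not among them. They also leave open how an amine or a carboxylic acid on this ring would read in this assay, and whether the same step would hold with a different group in place of the shared core's other parts.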